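From oxolan-3-yl to 2-hydroxy-2-methylbutyl on the shared core

A few compounds are considered here, and "the series" means these few. Any claim that something is new, unique, unknown or untested is made for them only; others in the source may bear on it.

In a functional assay on HeLa cells (Homo sapiens) for cytotoxicity, read by MTT assay (a higher number here means a weaker inhibitor, a lower number a stronger inhibitor), compound 1 (`COCCO[C@H](CC=C(C)C)C1=CC(=O)c2c(O)ccc(O)c2C1=O`) gives 62400 nM, compound 2 (`CC[C@](C)(O)CC(=O)O[C@H](CC=C(C)C)C1=CC(=O)c2c(O)ccc(O)c2C1=O`) gives 30200 nM, and compound 3 (`CC(C)=CC[C@@H](OC(=O)C1CCOC1)C1=CC(=O)c2c(O)ccc(O)c2C1=O`) gives 73500 nM. Compound 3 stands level with compound 1, as the measurements show a 1.2-fold higher number from compound 1 to compound 3 (0.07 log units; within the scatter). Compound 4 (`CC[C@@](C)(O)CC(=O)O[C@H](CC=C(C)C)C1=CC(=O)c2c(O)ccc(O)c2C1=O`) arises through one change, 2-hydroxy-2-methylbutyl in place of oxolan-3-yl on a carbonyl carbon. Compound 2 also carries a 2-hydroxy-2-methylbutyl group, so the closest guide is its measured step, read in reverse: a 2.4-fold higher number from compound 2 to compound 3 (0.39 log units; beyond the scatter). The step of a 2.1-fold lower number from compound 1 to compound 2 (0.32 log units; beyond the scatter) is of similar modest size. A modest fall in the number is therefore expected, namely a 2.2-fold lower number from compound 3 to compound 4 (0.33 log units; beyond the scatter). Compound 4 is estimated at 34000 nM, with an expected range of 18000 nM to 62000 nM.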

Compound 4, half-maximal inhibitory concentration: 17900 nM
Beside the measured number, compound 4's estimate is 1.9-fold (0.28 log units) above it, outside the stated range (below it).
By their numbers in this assay, from the lowest: compounds 4 and 2 (each within the scatter of the next); then compounds 1 and 3 (each within the scatter of the next).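

In this assay, 2-hydroxy-2-methylbutyl in place of oxolan-3-yl on a carbonyl carbon gives a 4.1-fold lower number from compound 3 to compound 4 (0.61 log units; beyond the scatter), the largest step yet seen at this position. Against the 2-methoxyethyl group on the oxygen, (2-hydroxy-2-methylbutyl)carbonyl gives a 3.5-fold lower number from compound 1 to compound 4 (0.54 log units; beyond the scatter). With the saturated chain stereocentre drawn R rather than S, the two numbers stay level, at a 1.7-fold lower number from compound 2 to compound 4 (0.23 log units; within the scatter), and this pair isolates that single feature: the fact that compounds 2 and 4 differ only in the configuration as drawn.

The compounds shown leave open whether the hydroxy group of 2-hydroxy-2-methylbutyl matters to this result. Going by these compounds, how a plain butyl chain, an amine or a carboxylic acid would read at this place also remains open.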